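A few compounds are considered here, and "the series" means these few. Any claim that something is new, unique, unknown or untested is made for them only; others in the source may bear on it.

Measured so far in a functional assay on SMMC-7721 cells (Homo sapiens) for inhibition, read by CCK-8 assay, with a stated time of 72 h, tested at 8 uM; on this read-out higher numbers stand for more inhibition of growth at the one concentration tested and lower numbers for less inhibition of growth:
compound 1 `Cc1ccc(SCc2ccc(/C=C/C(=O)Nc3ccccc3N)cc2)cc1` gives 22.2%
compound 2 `Nc1ccccc1NC(=O)/C=C/c1ccc(CSCCc2ccccc2)cc1` gives 15.8%

Compound 2 and compound 1 sit within the scatter of each other: a number 6.4 percentage points lower from compound 1 to compound 2 (within the scatter). Compound 3 `CCc1ccc(SCc2ccc(/C=C/C(=O)Nc3ccccc3N)cc2)cc1` differs from compound 2 by 4-ethylphenyl in place of phenethyl on a sulfur. For the measured compounds named here, only one measured step bears on this change, the one just named, and it was within the scatter. The 4-ethylphenyl of compound 3 resembles the 4-methylphenyl of compound 1 more than it does phenethyl, so compound 3 is expected near compound 1, with an expected step of a number 6.2 percentage points higher from compound 2 to compound 3 (within the scatter), not beyond the scatter. Compound 3 is therefore estimated at 22%, range 10% to 34%.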

Compound 3, percent growth inhibition at one concentration: 19.5%
Beside the measured number, compound 3's estimate is 2.5 percentage points above it; measured number inside the range.
By their numbers in this assay, from the lowest: compounds 2, 3 and 1 (each within the scatter of the next).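

In this assay, phenethyl and 4-ethylphenyl on the sulfur carry the same atoms joined differently, and this change gives a number 3.7 percentage points higher from compound 2 to compound 3 (within the scatter), so the new arrangement leaves the read-out unresolved from the old one. Methyl in place of hydrogen on a saturated chain carbon bound to an aromatic carbon gives a number 2.7 percentage points lower from compound 1 to compound 3 (within the scatter), so this extension is also unresolved at the one concentration tested. No supporting evidence bears on these steps.

Open, going by these compounds, is whether an amine or a carboxylic acid in place of the ethyl of 4-ethylphenyl would give a step beyond the scatter. Also open, on these data alone, is whether a longer chain there would do so.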